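Spirocyclic imides against mitochondrial phenylalanine-tRNA ligase: enantiomer check

A few compounds are considered here, and "the series" means these few. Any claim that something is new, unique, unknown or untested is made for them only; others in the source may bear on it.

Measured so far:
Compound 1 `O=C1[C@H]2C(c3ccccc3)NC3(Cc4ccccc4C3)[C@H]2C(=O)N1c1ccc(Cl)c(Cl)c1`: in an assay on isolated protein for inhibition of phenylalanine--tRNA ligase, mitochondrial (Homo sapiens) (a lower number here means a stronger inhibitor, a higher number a weaker inhibitor), compound 1 gives > 100000 nM, a limit of the assay rather than a number.
Compound 2 `O=C1[C@@H]2C(c3ccccc3)OC3(C(=O)c4ccccc4C3=O)[C@@H]2C(=O)N1c1ccc(Cl)c(C(F)(F)F)c1`: in this assay compound 2 gives > 100000 nM, likewise a limit.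

Within the data shown here, compound 1 stands only at a limit, and the other value shown is a limit too; no step between measured compounds can be drawn and no pattern is claimed. Compound 3 `O=C1[C@@H]2C(c3ccccc3)NC3(Cc4ccccc4C3)[C@@H]2C(=O)N1c1ccc(Cl)c(Cl)c1` differs from compound 1 as follows: the two compounds have the same atoms and bonds; at least one stereo element is drawn with a configuration in one of them and without one in the other: 2 of 3 stereo elements differ; a stereocentre at a saturated ring carbon is drawn R in compound 1 and S in compound 3; a stereocentre at a saturated ring carbon is drawn S in compound 1 and R in compound 3. Same atoms and bonds, opposite drawing at two ring stereocentres. In this assay the expected step of a number no higher from compound 1 to compound 3 (the limit leaves the size open) is none beyond the scatter, given that (the limit of > 100000 nM in this assay, at which 2 of the 2 values shown sit). Compound 3 is therefore expected at 100000 nM, between 10000 nM and 300000 nM, most likely reported as a limit again.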

Compound 3, half-maximal inhibitory concentration: > 100000 nM
Compound 3 was reported as a limit; the forecaster's own chance of this, stated with the estimate: 80%; the middle value lies on the limit itself.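

In this assay compound 3 gives > 100000 nM, a limit of the assay. Among these compounds, compound 1 also stands at a limit, so no step between compound 1 and compound 3 can be read. The compounds shown leave open whether either drawn configuration of the shared core gives any measurable inhibition.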